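The source may hold more compounds than are shown below. What is called first, only, known or untested is meant among the compounds shown, and "the series" means these compounds.

Three compounds sharing one core were tested in a functional assay on PC-3 cells (Homo sapiens) for antiproliferative activity, read by MTT assay, with a stated time of 48 h; on this read-out lower numbers stand for stronger inhibition and higher numbers for weaker inhibition. Compound 1 `Cc1cnc(Nc2ccc(S(C)(=O)=O)cc2)nc1Nc1nc2ccc(Cl)cc2s1` gives 13400 nM in this assay, the highest of the two plain numbers shown. Compound 3 `Cc1cnc(Nc2ccc(S(N)(=O)=O)cc2)nc1Nc1nc2ccc(Cl)cc2s1`, which carries amino in place of methyl on a sulfonyl sulfur, gives 5400 nM in this assay, and the step of a 2.5-fold lower number from compound 1 to compound 3 (0.39 log units; beyond the scatter) is modest. Compound 2 `Cc1cnc(Nc2ccc(S(C)(=O)=O)cc2)nc1Nc1nc2ccccc2s1` reaches only a limit of the assay, > 50000 nM, so its number is not known. The change from compound 1 to compound 2 is hydrogen in place of chloro on an aromatic carbon, and it amounts to an at least 3.7-fold higher number from compound 1 to compound 2 (0.57 log units; beyond the scatter); one of the three values sits at the limit of > 50000 nM in this assay, at which 1 of the 3 values shown sits.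

The unmeasured compound 4 `CS(=O)(=O)c1ccc(Nc2nccc(Nc3nc4ccc(Cl)cc4s3)n2)cc1` differs from compound 1 by hydrogen in place of methyl on an aromatic carbon. Neither measured step touches this methyl: one concerns the chloro, the other the sulfonyl group, so no direct guide exists for the size of this step. Both measured changes on this core moved the number beyond the scatter, so a shift of similar size would not be surprising, but its direction cannot be read from these data. For compound 4 the expected step is a 1.5-fold higher number from compound 1 to compound 4 (0.17 log units; within the scatter). Compound 4 is therefore estimated at 20000 nM, with a range from 6000 nM to 50000 nM.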

Compound 4, half-maximal inhibitory concentration: > 50000 nM
Compound 4 ended at the assay's limit; the forecaster's own chance of this, stated with the estimate: 25%; middle value at least 2.5-fold (0.39 log units) away from the limit.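

Within the data shown here, the earlier steps touched only the chloro and the sulfonyl group, so this is the first view of the methyl on the six-membered aromatic ring with 2 nitrogen, and replacing it with hydrogen gives an at least 3.7-fold higher number from compound 1 to compound 4 (0.57 log units; beyond the scatter). In this assay, going by these compounds, compound 4 sits at a limit of the assay, > 50000 nM, so the true size of this step stays unknown and it could be larger than printed. A single carbon is therefore no bystander on this core: compound 1 keeps a measurable number with its methyl, while without it compound 4 joins compound 2 at the same ceiling: the limit of > 50000 nM in this assay, at which 2 of the 4 values shown sit.

Still open, on these data alone, is whether only the methyl serves at this place, or whether an ethyl, a fluoro or a methoxy on the same aromatic carbon would keep a measurable number as well. Also open, as far as these compounds go, is whether hydrogen in place of this methyl would cost as much in compound 3, which carries amino on the sulfonyl sulfur and has the lower number of the two measured chloro compounds.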